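Glycine transporter inhibitors: swapping chlorophenyl for thiazolyl

A few compounds are considered here, and "the series" means these few. Any claim that something is new, unique, unknown or untested is made for them only; others in the source may bear on it.

Measured so far:
Compound 1 `O=C(CNC(=O)c1ccsc1)NC(c1ccccc1)c1ccc(Cl)cc1` gives 89 nM in an assay for inhibition of sodium- and chloride-dependent glycine transporter 1 (Homo sapiens); on this read-out higher numbers stand for an effect only at larger amounts of compound and lower numbers for an effect already at smaller amounts.
Compound 2 `O=C(CNC(=O)c1ccc(F)cc1)NC(c1ccccc1)c1ccccc1` gives 110 nM in this assay.
Compound 3 `O=C(CNC(=O)c1ccc(F)cc1)NC(c1ccccc1)c1cccc(Cl)c1` gives 33 nM in this assay.

Compound 3 stands lowest of the three numbers: compound 1 sits a step above it and compound 2 a larger step above it, both gaps beyond the usual scatter. Within the data shown here, the one single-point step among the measured compounds is a 3.3-fold lower number from compound 2 to compound 3 (0.52 log units; beyond the scatter), a modest gain.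

Compound 4 `O=C(CNC(=O)c1ccc(F)cc1)NC(c1ccccc1)c1nccs1` differs from compound 3 by 1,3-thiazol-2-yl in place of 3-chlorophenyl on a saturated chain carbon bound to an amide-type nitrogen and an aromatic carbon. Among the measured compounds shown here, no measured step bears directly on this exchange; the only related step is the one from compound 2 to compound 3, which shows what the chloro contributes on that ring. Compound 4 loses that chloro and changes the ring itself, so the gain seen in a 3.3-fold lower number from compound 2 to compound 3 (0.52 log units; beyond the scatter) is expected to be given back, and the different ring may shift the number further in either direction. The step from compound 3 to compound 4 is therefore expected to be a 4.5-fold higher number from compound 3 to compound 4 (0.66 log units; beyond the scatter), toward higher numbers. For compound 4 an estimated value of 150 nM is expected, within a range from 40 nM to 600 nM.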

Compound 4, half-maximal effective concentration: 5050 nM
Beside the measured number, compound 4's estimate is 34-fold (1.53 log units) below it; the whole stated range lies below it.
By their numbers in this assay, from the lowest: compound 3; then compounds 1 and 2 (each within the scatter of the next); then compound 4.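

In this assay the ring on the saturated chain carbon bound to an amide-type nitrogen and an aromatic carbon turns out to matter far more than its chloro: 1,3-thiazol-2-yl in place of 3-chlorophenyl gives a 150-fold higher number from compound 3 to compound 4 (2.18 log units; beyond the scatter) as a large step, whereas the chloro alone accounted for a 3.3-fold lower number from compound 2 to compound 3 (0.52 log units; beyond the scatter) as a modest one. Even against plain phenyl, 1,3-thiazol-2-yl gives a 46-fold higher number from compound 2 to compound 4 (1.66 log units; beyond the scatter) as a large step, so the exchange of the ring itself, and not the missing chloro, carries most of the change. Nothing at hand explains why this exchange costs so much.

From the compounds shown here alone, it remains open whether the loss is specific to 1,3-thiazol-2-yl or would follow any departure from the six-membered carbon ring at this place, a question that a pyridin-2-yl or a cyclohexyl group there would help to settle. Also open, going by these compounds, is whether a chloro or a methyl on the 1,3-thiazol-2-yl ring would recover any of the lost ground.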